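This account rests on a few compounds, and the source may have more. Where it says the series, first, only, none or still open, it means among the compounds named here.

Measured in a functional assay on MCF cells (Homo sapiens) for antiproliferative activity, with a stated time of 72 h; on this read-out higher numbers stand for weaker inhibition and lower numbers for stronger inhibition:
- compound 1 `OC[C@H]1O[C@@H](n2cnc3c(NCc4ccc(Cl)cc4)ncnc32)[C@H](O)[C@@H]1O`: > 166000 nM (a limit)
- compound 2 `OC[C@H]1O[C@@H](n2cnc3c(NCc4ccc(Cl)c(Cl)c4)ncnc32)[C@H](O)[C@@H]1O`: 88800 nM

Among the compounds with values here, compound 2, at 88800 nM, holds the only actual number. Compound 3 `COc1cc(CNc2ncnc3c2ncn3[C@@H]2O[C@H](CO)[C@@H](O)[C@H]2O)cc(OC)c1` carries 3,5-dimethoxyphenyl in place of 3,4-dichlorophenyl on a saturated chain carbon bound to a nitrogen on an aromatic ring. Within the data shown here, one measured step bears on this, an at least 1.8-fold lower number from compound 1 to compound 2 (0.27 log units; that floor lies within the scatter), with chloro in place of hydrogen on an aromatic carbon. It rests on (the limit of > 166000 nM in this assay, at which 1 of the 2 values shown sits), and it involves no methoxy group, so it gives no firm direction. No shift beyond the scatter is expected in this assay. The expected step is a 1.1-fold higher number from compound 2 to compound 3 (0.05 log units; within the scatter). The estimate for compound 3 is 100000 nM, with an expected range of 35000 nM to 200000 nM.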

Compound 3, half-maximal inhibitory concentration: > 166000 nM
Compound 3: no number, only a limit (the forecaster's own chance of this, stated with the estimate: 35%); middle value at least 1.6-fold (0.22 log units) away from the limit.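

In this assay, within the data shown here, the first oxygen-bearing group at this place, 3,5-dimethoxyphenyl in place of 3,4-dichlorophenyl, gives an at least 1.8-fold higher number from compound 2 to compound 3 (0.27 log units; that floor lies within the scatter). Compound 3 gives > 166000 nM, which is a limit and not a number. Only compound 2 still gives a number, and the step between compound 1 and compound 3 cannot be read: the limit of > 166000 nM in this assay, at which 2 of the 3 values shown sit.

The size of any difference among these aryl groups stays open. So does how a carboxylic acid or an amine on the phenyl ring, or a longer chain at this place, would read.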